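Methoxy removal in the second selenophene isomer

The source may hold more compounds than are shown below. What is called first, only, known or untested is meant among the compounds shown, and "the series" means these compounds.

Within the data shown here, compound 3 `COc1ccc2[nH]c(-c3cc[se]c3)cc(=O)c2c1OC` gives 100000 nM in a functional assay on Hep 3B2 cells (Homo sapiens) for cytotoxicity, read by MTT assay, with a stated time of 48 h (a higher number here means a weaker inhibitor, a lower number a stronger inhibitor), the higher of the two numbers read so far. Compound 2 `COc1ccc2[nH]c(-c3ccc[se]3)cc(=O)c2c1` gives 3200 nM in this assay. For compound 1 `COc1ccc2[nH]c(-c3ccc[se]3)cc(=O)c2c1OC` this assay reports only a limit, > 100000 nM. The step from compound 1 to compound 3 is a number no higher from compound 1 to compound 3 (the limit leaves the size open), the limit of > 100000 nM in this assay, at which 1 of the 3 values shown sits, leaving its size unreadable. Compound 4 `COc1ccc2[nH]c(-c3cc[se]c3)cc(=O)c2c1` differs from compound 3 by hydrogen in place of methoxy on an aromatic carbon. The same change has been measured once in the other isomer: an at least 31-fold lower number from compound 1 to compound 2 (1.49 log units; beyond the scatter). A large drop of comparable size is therefore expected in this assay, though the limit of > 100000 nM in this assay, at which 1 of the 3 values shown sits, makes its true extent uncertain. Compound 4 is estimated at 4000 nM, expected between 1000 nM and 25000 nM. This corresponds to an expected step of a 25-fold lower number from compound 3 to compound 4 (1.40 log units; beyond the scatter).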

Compound 4, half-maximal inhibitory concentration: 3700 nM
Estimate against measurement, compound 4: 1.1-fold (0.03 log units) above; measured number inside the range.
By their numbers in this assay, from the lowest: compounds 2 and 4 (each within the scatter of the next); then compound 3.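

In this assay, hydrogen in place of methoxy on this aromatic carbon now has a readable size, a 27-fold lower number from compound 3 to compound 4 (1.43 log units; beyond the scatter). The drop is therefore not confined to one selenophene isomer: the same change on two cores in this assay, an at least 31-fold lower number (1.49 log units; beyond the scatter) from compound 1 to compound 2 and a 27-fold lower number (1.43 log units; beyond the scatter) from compound 3 to compound 4; the limit leaves it open whether they differ Once the methoxy is gone, swapping the isomer gives a 1.2-fold higher number from compound 2 to compound 4 (0.06 log units; within the scatter), so this assay does not separate the two isomers.

Compound 1 gives > 100000 nM, which is a limit, and the steps from it cannot be read. As far as these compounds go, whether a hydroxyl, fluorine or an amine on this aromatic carbon would match hydrogen remains open.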